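The source may hold more compounds than are shown below. What is called first, only, known or untested is meant among the compounds shown, and "the series" means these compounds.

In an assay on isolated protein for displacement of a labelled ligand from Gonadotropin-releasing hormone receptor (Rattus norvegicus) (a higher number here means a weaker inhibitor, a lower number a stronger inhibitor), compound 1 `Cc1nc(C)c(CN2CCN(c3cccc4[nH]c(-c5ccc(C(C)(C)C)cc5)nc34)CC2)o1` gives 740 nM, compound 2 `CCc1nc(C)c(CN2CCN(c3cccc4[nH]c(-c5ccc(C(C)(C)C)cc5)nc34)CC2)o1` gives 320 nM, and compound 3 `CCCCn1cnc(CN2CCN(c3cccc4[nH]c(-c5ccc(C(C)(C)C)cc5)nc34)CC2)c1C` gives 49 nM. Compound 2 thus stands second highest of the three, set apart by a 2.3-fold lower number from compound 1 to compound 2 (0.36 log units; beyond the scatter) on one side and a 6.5-fold lower number from compound 2 to compound 3 (0.81 log units; beyond the scatter) on the other. Compound 4 `CCn1cc(CN2CCN(c3cccc4[nH]c(-c5ccc(C(C)(C)C)cc5)nc34)CC2)nc1C` has not yet been measured; it carries 1-ethyl-2-methyl-1H-imidazol-4-yl in place of 2-ethyl-4-methyl-1,3-oxazol-5-yl on a saturated chain carbon bound to an amine nitrogen in a ring. The step that bears most directly on this change is the replacement of the 1,3-oxazol-5-yl ring by a 1H-imidazol-4-yl ring seen in a 6.5-fold lower number from compound 2 to compound 3 (0.81 log units; beyond the scatter), with a 15-fold lower number from compound 1 to compound 3 (1.18 log units; beyond the scatter) pointing the same way. Because of a 6.5-fold lower number from compound 2 to compound 3 (0.81 log units; beyond the scatter) a lower number is expected for compound 4 in this assay, though the ethyl and methyl groups on its imidazole differ from those of compound 3, so a smaller drop is anticipated. Compound 4 is therefore estimated at 120 nM, between 40 nM and 400 nM, a step of a 2.7-fold lower number from compound 2 to compound 4 (0.43 log units; beyond the scatter).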

Compound 4, half-maximal inhibitory concentration: 51 nM
The estimate for compound 4 lay 2.4-fold (0.37 log units) above the measured number; the range from low to high includes it.
By their numbers in this assay, from the lowest: compounds 3 and 4 (each within the scatter of the next); then compound 2; then compound 1.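

In this assay, the gain from replacing an oxazole with an imidazole does not depend on the 1-butyl-5-methyl-1H-imidazol-4-yl group alone: 1-ethyl-2-methyl-1H-imidazol-4-yl also gives a 6.3-fold lower number from compound 2 to compound 4 (0.80 log units; beyond the scatter) and a 15-fold lower number from compound 1 to compound 4 (1.16 log units; beyond the scatter). The two imidazole groups are not told apart here, with a 1.0-fold higher number from compound 3 to compound 4 (0.02 log units; within the scatter), so this position tolerates both arrangements of their alkyl groups. No supporting data explain these steps. Going by these compounds, whether a thiazole ring would match the imidazoles remains open. So does whether a hydroxyethyl or longer hexyl chain on the imidazole would keep the same level.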